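The source may hold more compounds than are shown below. What is called first, only, known or untested is meant among the compounds shown, and "the series" means these compounds.

Compound 1, `CCOC(=O)C1=Cc2ccccc2OC1(OCc1cc(-c2ccc(C)cc2)no1)C(F)(F)F`, in a functional assay on A549 cells (Homo sapiens) for inhibition, read by MTT assay, with a stated time of 24 h (a lower number here means a stronger inhibitor, a higher number a weaker inhibitor), gave only a limit, > 150000 nM.
Compound 2, `CCOC(=O)C1=Cc2ccccc2OC1(OCc1cn(CC(=O)Nc2ccc(C)cc2)nn1)C(F)(F)F`, in this assay gave 54300 nM.
Compound 3, `Cc1ccc(-c2cc(COC3(C(F)(F)F)Oc4ccccc4C=C3C(=O)O)on2)cc1`, in this assay gave 51200 nM.

Of the two numbers in this assay, compound 3 has the lower, but compound 2 sits so close that the two cannot be told apart; the third value is the limit of compound 1, (the limit of > 150000 nM in this assay, at which 1 of the 3 values shown sits). Going by the values given here, the one measured step, an at least 2.9-fold lower number from compound 1 to compound 3 (0.46 log units; beyond the scatter), changes the ethyl ester of compound 1 into the free acid of compound 3 and is the only step beyond the scatter.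

Compound 4, `O=C(O)C1=Cc2ccccc2OC1(OCc1cc(-c2ccc(F)cc2)no1)C(F)(F)F`, differs from compound 3 by fluoro in place of methyl on an aromatic carbon. Among the compounds with values here, no measured step touches this part of the shared core, so there is no basis for expecting a shift in this assay either way; the expectation is for a step within the scatter. The estimated step is a 1.0-fold lower number from compound 3 to compound 4 (0.00 log units; within the scatter), taken as no change. For compound 4 the estimate in this assay is 51000 nM, with a range from 18000 nM to 140000 nM.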

Compound 4, half-maximal inhibitory concentration: > 150000 nM
Compound 4: a limit, no number; the forecaster's own chance of this, stated with the estimate: 15%; at least 2.9-fold (0.46 log units) between middle value and limit.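

Going by these compounds alone, compound 1 and compound 3 both carry methyl on this aromatic ring, so the earlier compounds said nothing about this position. Going from 4-methylphenyl to 4-fluorophenyl, a change of a single heavy atom, gives an at least 2.9-fold higher number from compound 3 to compound 4 (0.46 log units; beyond the scatter) in this assay, so the position is not silent. The free acid alone therefore does not secure a measured number, and compound 4, which keeps that acid, joins compound 1 at a limit, leaving the full size of the step unread: the limit of > 150000 nM in this assay, at which 2 of the 4 values shown sit.

The compounds shown leave open whether losing methyl or gaining fluoro drives this step, a question that hydrogen, chloro or methoxy at this place could help settle. Also open, from the compounds shown here alone, is whether the same swap would shift the number for compound 2, which carries its 4-methylphenyl group on an amide.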